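A hydroxy group joins the shared core

A few compounds are considered here, and "the series" means these few. Any claim that something is new, unique, unknown or untested is made for them only; others in the source may bear on it.

Compound 1 `O=C(Nc1ccc(Sc2nc3ccccc3s2)c(Cl)c1)c1cccc(Br)c1`: in an assay for inhibition of HSP60/HSP10 (Homo sapiens), with a stated time of 60 min (on this read-out lower numbers stand for stronger inhibition and higher numbers for weaker inhibition), compound 1 gives > 100000 nM, which is a limit of the assay and not a number.
Compound 2 `O=C(Nc1ccc(Sc2nc3ccccc3s2)cc1)c1cccc(Br)c1`: in this assay compound 2 gives > 100000 nM, again only a limit.

Both results sit at the limit of > 100000 nM in this assay, at which 2 of the 2 values shown sit, so compound 2 stands only at that limit. Among the measured compounds shown here, the one measured step, a step that the two limits leave unreadable from compound 1 to compound 2, is therefore unreadable. Compound 3 `O=C(Nc1ccc(Sc2nc3ccccc3s2)cc1)c1cccc(Br)c1O` differs from compound 2 by hydroxy in place of hydrogen on an aromatic carbon. For the measured compounds named here, no measured step speaks to a hydroxy group here, so nothing points to a gain. The expected step is a number no higher from compound 2 to compound 3 (the limit leaves the size open). Compound 3 is expected to give 100000 nM, with a range from 30000 nM to 300000 nM.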

Compound 3, half-maximal inhibitory concentration: 26000 nM
Estimate against measurement, compound 3: 3.8-fold (0.59 log units) above; measured number below the stated range.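

Among the compounds shown here, changing 3-bromophenyl to 3-bromo-2-hydroxyphenyl gives, in this assay, the first readable step: an at least 3.8-fold lower number from compound 2 to compound 3 (0.58 log units; beyond the scatter). A single hydroxy group at this position is thus enough to bring the number off the assay limit, and compound 3 is the only compound shown with a real number. The full size of the step stays unknown because compound 2 stands only at a limit: the limit of > 100000 nM in this assay, at which 2 of the 3 values shown sit.

From the compounds shown here alone, whether a methoxy group or an amine at the same place would give a similar step stays open. Also open, going by these compounds, is whether the hydroxy group gives any step when the bromo group is absent.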